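A few compounds are considered here, and "the series" means these few. Any claim that something is new, unique, unknown or untested is made for them only; others in the source may bear on it.

Values so far in a functional assay on CNE-2 cells (Homo sapiens) for antiproliferative activity, read by sulforhodamine B assay, with a stated time of 48 h; a higher number here means a weaker inhibitor, a lower number a stronger inhibitor:
- compound 1 `COc1cc(C=C(C(=O)/C=C/c2cccc(OC)c2OC)C(=O)/C=C/c2cccc(OC)c2OC)cc(OC)c1O` gives 300 nM 
- compound 2 `COc1ccc(/C=C/C(=O)C(=Cc2ccc(O)c(OC)c2)C(=O)/C=C/c2ccc(OC)cc2OC)c(OC)c1` gives 970 nM 

Compound 2 has the higher number of the two, which makes it the weaker inhibitor of this pair, and the gap lies beyond the scatter. The two compounds differ in more than one place, so no single change can be read from them.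

Compound 3 `COc1ccc(/C=C/C(=O)C(=Cc2ccc(O)c(F)c2)C(=O)/C=C/c2ccc(OC)cc2OC)c(OC)c1` departs from compound 2 in one place only, with fluoro in place of methoxy on an aromatic carbon, ortho to a hydroxy group. This takes 4-hydroxy-3-methoxyphenyl to 3-fluoro-4-hydroxyphenyl fluoro in place of methoxy on an aromatic carbon and leaves the rest of the structure unchanged.

Within the data shown here, no measured step covers this change, so the expectation rests on compound 2 at 970 nM alone. Expected here is a 1.2-fold lower number from compound 2 to compound 3 (0.08 log units; within the scatter) in this assay as a change that stays inside the scatter, with no firm direction. For compound 3 the estimated value is 800 nM with an expected range of 250 nM to 2500 nM around it.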

Compound 3, half-maximal inhibitory concentration: 2830 nM
Estimate against measurement, compound 3: 3.5-fold (0.55 log units) below, and the stated range ends below it.
By their numbers in this assay, from the lowest: compound 1; then compound 2; then compound 3.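

In this assay, among these compounds, this is the first single change the series allows to be read, and the place ortho to a hydroxy group proves sensitive to what stands on it: fluoro in place of methoxy gives a 2.9-fold higher number from compound 2 to compound 3 (0.47 log units; beyond the scatter). The step runs towards the weaker inhibitor, so with the rest of the structure held constant, 4-hydroxy-3-methoxyphenyl outperforms 3-fluoro-4-hydroxyphenyl in this pair, and the step is modest but beyond the scatter. No measurement at hand speaks to what lies behind this step, so it stands as an observation on one pair only.

A single step cannot tell whether methoxy helps at this place or fluoro harms, and a bare hydrogen, a chloro, an ethoxy or an amine on the same aromatic carbon would separate those two readings. Also open, from the compounds shown here alone, is whether the same exchange carries the same penalty on the core of compound 1, whose other aromatic groups differ from those of compound 2 and compound 3.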